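The source may hold more compounds than are shown below. What is called first, only, known or untested is meant among the compounds shown, and "the series" means these compounds.

Compound 1 `C=CCN1C(=O)C(=O)c2cc(-c3ccc(OC)cc3)ccc21` carries a vinyl group on a saturated chain carbon bound to an amide-type nitrogen in a ring. In a functional assay on HepG2 cells (Homo sapiens) for antiproliferative activity, read by MTT assay, with a stated time of 48 h (a higher number here means a weaker inhibitor, a lower number a stronger inhibitor), compound 1 gives 7090 nM. Compound 2 `COc1ccc(-c2ccc3c(c2)C(=O)C(=O)N3Cc2cccc(OC)c2)cc1` bears 3-methoxyphenyl in place of that vinyl, and in this assay compound 2 gives 700 nM, a change of a 10-fold lower number from compound 1 to compound 2 (1.01 log units; beyond the scatter). Compound 3 `COc1ccc(CN2C(=O)C(=O)c3cc(-c4ccc(OC)c(OC)c4)ccc32)cc1` differs from compound 2 in two places at once. In this assay compound 3 gives only a limit, > 10000 nM, which is the limit of > 10000 nM in this assay, at which 1 of the 3 values shown sits, so its true value is not known.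

Compound 4 `COc1ccc(CN2C(=O)C(=O)c3cc(-c4ccncc4)ccc32)cc1` is the next step from compound 3: pyridin-4-yl in place of 3,4-dimethoxyphenyl on an aromatic carbon. For the measured compounds named here, the one measured step, from compound 1 to compound 2, changes a different place of the shared core and does not bear on this aromatic carbon. Compound 2, which carries 4-methoxyphenyl at this aromatic carbon, gives 700 nM. Compound 3, with the 3,4-dimethoxyphenyl, gives only a limit. Compound 4 is therefore expected to land at about 5000 nM, within a range from 1000 nM to 20000 nM. The step this estimate means, an at least 2.0-fold lower number from compound 3 to compound 4 (0.30 log units; that floor lies within the scatter), is an expectation only, and a limit rather than a number remains a real possibility.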

Compound 4, half-maximal inhibitory concentration: > 10000 nM
Compound 4: only a limit was reported (the forecaster's own chance of this, stated with the estimate: 35%); at least 2.0-fold (0.30 log units) between middle value and limit.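

Compound 3 and compound 4 each give only a limit in this assay, so no step can be read between them: the limit of > 10000 nM in this assay, at which 2 of the 4 values shown sit.

The compounds shown leave open how pyridin-4-yl and 3,4-dimethoxyphenyl compare on this aromatic carbon in this assay.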